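Swapping 4-hydroxyphenyl for pyridin-3-yl at the assay limit

This account rests on a few compounds, and the source may have more. Where it says the series, first, only, none or still open, it means among the compounds named here.

In an ADME assay on BJ cells (Homo sapiens) for cytotoxicity, with a stated time of 72 h (on this read-out lower numbers stand for an effect already at smaller amounts and higher numbers for an effect only at larger amounts of compound), compound 1 `Cc1ccc(NC(=O)Nc2cc(C)nc3ccccc23)cc1` gives > 25000 nM, which is a limit. Compound 2 `Cc1cc(NC(=O)Nc2ccc(O)cc2)c2ccccc2n1` gives > 25000 nM, which is also a limit, so its position is known only as a bound. Compound 3 `Cc1cc(NC(=O)Nc2cccnc2)c2ccccc2n1` differs from compound 2 as follows: pyridin-3-yl in place of 4-hydroxyphenyl on an amide-type nitrogen. Among the compounds with values here, the one measured step is a step that the two limits leave unreadable from compound 1 to compound 2, and it fixes no size; the evidence is the limit of > 25000 nM in this assay, at which 2 of the 2 values shown sit. A step beyond the usual scatter in this assay is therefore not expected, and the estimated change is a number no higher from compound 2 to compound 3 (the limit leaves the size open). For compound 3 the estimated value is 25000 nM, within an expected range of 12000 nM to 25000 nM.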

Compound 3, half-maximal effective concentration: > 25000 nM
Compound 3: no number, only a limit; the forecaster's own chance of this, stated with the estimate: 85%; the middle value sits exactly at the limit.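

Compound 3 gives > 25000 nM in this assay, which is a limit, so no step can be read among compound 1, compound 2 and compound 3. The compounds shown leave open whether these three differ at all, and by how much.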